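The compounds below may be only part of what the source reports. "The series", "measured", "known", "first", "only" and "open" are said of these compounds alone.

Working notes on the series. Of the compounds shown here, three share one core and have been measured in a functional assay on PANC-1 cells (Homo sapiens) for inhibition, read by MTT assay, with a stated time of 24 h, tested at 10 uM; on this read-out lower numbers stand for less inhibition and higher numbers for more inhibition at the one concentration tested (going by the name of the read-out). Compound 1 `CCOc1cc(=O)n(CCCO)c2c1CC(C/C=C(\C)CCC=C(C)C)C(C)(C)C2` gives 67.8%. Compound 2 `CC(C)=CCC/C(C)=C/CC1Cc2c(OCC=C(C)C)cc(=O)n(CCCO)c2CC1(C)C` gives 30.3%. Compound 3 `COc1ccc(C(=O)NCCCOc2cc(=O)n(CCCO)c3c2CC(C/C=C(\C)CCC=C(C)C)C(C)(C)C3)cc1` gives 45.7%. Compound 3 stands second highest of the three: the nearest number is that of compound 2 and the furthest that of compound 1, both gaps beyond the scatter.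

Within the data shown here, the two steps so far both lower the read-out. The step of a number 37.5 percentage points lower from compound 1 to compound 2 (beyond the scatter) is large. The step of a number 22.1 percentage points lower from compound 1 to compound 3 (beyond the scatter) is modest and is the one that bears on the next compound, since it builds out the same chain on the ether oxygen.

Compound 4 `COc1ccc(OCCCOc2cc(=O)n(CCCO)c3c2CC(C/C=C(\C)CCC=C(C)C)C(C)(C)C3)cc1` is not yet measured. It differs from compound 3 thus: 4-methoxyphenoxy in place of ((4-methoxyphenyl)carbonyl)amino on a saturated chain carbon, three bonds along the chain from an oxygen on an aromatic ring. The tail keeps one six-membered aromatic ring of carbon only and two hydrogen-bond acceptors, loses the hydrogen-bond donor and two heavy atoms. Among the measured compounds shown here, no measured step in this assay swaps one such tail for another; only the addition of a tail, from compound 1 to compound 3, is known. The chain stays of similar length, so only a small step is expected, within the scatter, in either direction. The expected step is a number 2.7 percentage points lower from compound 3 to compound 4 (within the scatter). Compound 4 is therefore estimated at 43%, with a range from 26% to 60%.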

Compound 4, a percentage reported as inhibition, at one concentration (the size of the read-out at that concentration, not a potency): 20%
Beside the measured number, compound 4's estimate is 23 percentage points above it; the whole stated range lies above it.
By their numbers in this assay, from the lowest: compound 4; then compound 2; then compound 3; then compound 1.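

In this assay, the tail on the ether oxygen proves not to be interchangeable: 4-methoxyphenoxy in place of ((4-methoxyphenyl)carbonyl)amino gives a number 25.7 percentage points lower from compound 3 to compound 4 (beyond the scatter), although both tails hold one six-membered aromatic ring of carbon only and the chain stays of similar length. Set against the core of compound 1, the two tails therefore do not count alike, with a number 47.8 percentage points lower from compound 1 to compound 4 (beyond the scatter) for the new tail and a number 22.1 percentage points lower from compound 1 to compound 3 (beyond the scatter) for the earlier one, so the fall seen on adding a tail depends on how that tail is joined. The step of a number 10.3 percentage points lower from compound 2 to compound 4 (beyond the scatter) leaves this tail the lowest of the four, with its steps to all the others beyond the scatter.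

No measurement at hand accounts for the gap between the two tails. Still open, going by these compounds, is whether the loss follows the amide hydrogen or the change of linking atoms as a whole, which an amide with a methyl on its nitrogen would separate, and how a longer chain, an amine or a carboxylic acid in the tail would read.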